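Working notes: nitrile for dichloro on a bis-amide core

A few compounds are considered here, and "the series" means these few. Any claim that something is new, unique, unknown or untested is made for them only; others in the source may bear on it.

Compound 1 `O=C(Nc1ccccc1O)c1cccc(N2C(=O)c3ccccc3C2=O)c1` — 77 nM
Compound 2 `O=C(Nc1ccc(Cl)c(-c2nc3ccccc3[nH]2)c1)c1ccc(Br)o1` — 85 nM
Compound 3 `COc1ccccc1C(=O)Nc1cccc(NC(=O)c2ccc(Cl)c(Cl)c2)c1` — > 30000 nM

In an in vitro functional assay on HEK293-A cells for antagonist activity at metabotropic glutamate receptor 5 (Rattus norvegicus), read by calcium flux (a higher number here means a weaker inhibitor, a lower number a stronger inhibitor), compound 1 gives 77 nM and compound 2 gives 85 nM; these two lie within the scatter of each other, so no order between them is claimed. Compound 3 returns only a limit in this assay, > 30000 nM, and no number. That limit is the point described by the limit of > 30000 nM in this assay, at which 1 of the 3 values shown sits, so compound 3 stands apart from the other two as the one entry without a measured value. For the measured compounds named here, no pair among the three measured compounds differs in a single place, so no measured step is available to read a trend from.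

Compound 4 `COc1ccccc1C(=O)Nc1cccc(NC(=O)c2cccc(C#N)c2)c1` is not yet measured. It differs from compound 3 by 3-cyanophenyl in place of 3,4-dichlorophenyl on a carbonyl carbon. With compound 3 recorded only as a limit, the size of this step cannot be anchored to a measured pair, and the shared core of compound 3 has so far shown no number at all. The step expected in this assay is an at least 1.5-fold lower number from compound 3 to compound 4 (0.17 log units; that floor lies within the scatter), a change not expected to carry the compound clearly beyond the scatter in either direction. Compound 4 is therefore expected near 20000 nM, within 3000 nM to 100000 nM, with a second limit rather than a number the likelier outcome.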

Compound 4, half-maximal inhibitory concentration: 1800 nM
For compound 4 the middle estimate is 11-fold (1.05 log units) above the measured one; measured number outside the range, below it.
By their numbers in this assay, from the lowest: compounds 1 and 2 (each within the scatter of the next); then compound 4. At a limit, above all of these: compound 3.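

In this assay, for the compounds shown here, 3-cyanophenyl in place of 3,4-dichlorophenyl on a carbonyl carbon gives an at least 16-fold lower number from compound 3 to compound 4 (1.22 log units; beyond the scatter), the first measured step in this set and the first sign that this position matters on this bis-amide core. Going by these compounds alone, with this change the shared core of compound 3 also yields a number for the first time, as compound 4 gives 1800 nM in this assay, which shows that the core itself can register in this read-out once the group on this carbonyl carbon is changed. The entry for compound 3 is a limit and not a number, and the step therefore fixes only a floor on the size of the change, with its true size unknown: the limit of > 30000 nM in this assay, at which 1 of the 4 values shown sits.

On these data alone, the step swaps the whole aryl group at once, and it remains open whether the gain follows the nitrile's arrival or the loss of either chlorine; 3-chlorophenyl, 4-chlorophenyl and 4-cyanophenyl at this place would separate these readings. Also open, as far as these compounds go, is how far this position tolerates other groups, such as a carboxylic acid or an amine on the same ring, and compounds 1 and 2 differ from compound 4 in more than one place and offer no reading on this.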